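Removing a Trifluoromethyl Group: Expected Effect on Cell Growth

A few compounds are considered here, and "the series" means these few. Any claim that something is new, unique, unknown or untested is made for them only; others in the source may bear on it.

Measured compounds:
compound 1 `Fc1ccc(C2CC(c3ccc(Cl)s3)=NN2c2nc(-c3ccc(C(F)(F)F)cc3)cs2)cc1` gives > 500 ug/mL in a functional assay on A549 cells (Homo sapiens) for antiproliferative activity, read by XTT assay, with a stated time of 24 h; on this read-out lower numbers stand for stronger inhibition and higher numbers for weaker inhibition
compound 2 `Cc1ccc(C2=NN(c3nc(-c4ccc([N+](=O)[O-])cc4)cs3)C(c3ccc(F)cc3)C2)s1` gives 16.7 ug/mL
compound 3 `Cc1ccc(C2=NN(c3nc(-c4ccc(C(F)(F)F)cc4)cs3)C(c3ccc(F)cc3)C2)s1` gives > 500 ug/mL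

The value of compound 1 is a limit of the assay, not a number. The value of compound 3 is likewise a limit. Within the data shown here, compound 2 is the only one with a measured number. The step that the two limits leave unreadable from compound 1 to compound 3 cannot be read, which is stated in the limit of > 500 ug/mL in this assay, at which 2 of the 3 values shown sit. The step of an at least 29-fold higher number from compound 2 to compound 3 (1.47 log units; beyond the scatter) is large.

Compound 4 `Fc1ccc(C2CC(c3ccc(Cl)s3)=NN2c2nc(-c3ccccc3)cs2)cc1` differs from compound 1 as follows: hydrogen in place of trifluoromethyl on an aromatic carbon. Among the measured compounds shown here, none of the measured steps covers this exact change; the step of an at least 29-fold higher number from compound 2 to compound 3 (1.47 log units; beyond the scatter) is the only one at that position and shows that exchanging the group there can move the number far. Compound 4 is therefore expected to remain near the limit, giving 300 ug/mL (range 30 ug/mL to 600 ug/mL), with the step of an at least 1.6-fold lower number from compound 1 to compound 4 (0.22 log units; that floor lies within the scatter) estimated as no clear change.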

Compound 4, half-maximal inhibitory concentration: > 500 ug/mL
Compound 4 was reported as a limit; the forecaster's own chance of this, stated with the estimate: 60%; middle value at least 1.6-fold (0.22 log units) away from the limit.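

Compound 1 and compound 4 each give only a limit of the assay, not a number, so no step between them can be read: the limit of > 500 ug/mL in this assay, at which 3 of the 4 values shown sit.

The compounds shown leave open whether hydrogen in place of trifluoromethyl changes growth inhibition at all.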